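Notes on the step from compound 3 to compound 4

The source may hold more compounds than are shown below. What is called first, only, known or untested is meant among the compounds shown, and "the series" means these compounds.

Measured in a functional assay on Huh-7 cells (Homo sapiens) for cytotoxicity, read by MTT assay, with a stated time of 72 h (on this read-out higher numbers stand for lower toxicity in this test and lower numbers for higher toxicity in this test), as follows
- compound 1 `O=S(=O)(Cc1ccccc1)N1CCC2(CC1)OOC1(CCCC1)OO2` gives > 100 ug/mL as a limit
- compound 2 `Cc1ccc(S(=O)(=O)N2CCC3(CC2)OOC2(CCCCCC2)OO3)cc1` gives > 100 ug/mL as a limit
- compound 3 `CCCS(=O)(=O)N1CCC2(CC1)OOC(C)(C)OO2` gives > 100 ug/mL as a limit

Compound 3 stands at > 100 ug/mL as a limit of this assay and not as a number. For the measured compounds named here, the series so far shows the limit of > 100 ug/mL in this assay, at which 3 of the 3 values shown sit, and no numeric value.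

Compound 4 `CCCS(=O)(=O)N1CCC2(CC1)OOC(C)(C(C)C)OO2` has isopropyl in place of methyl on a saturated ring carbon, counted as isopropyl in place of methyl on a saturated ring carbon in the two structures.

Going by the values given here, no measured step between two compounds gives the size of such a change. The expectation rests on compound 3 and its > 100 ug/mL as a limit. No step beyond the scatter is expected in this assay for this change, and the estimated step is a number no higher from compound 3 to compound 4 (the limit leaves the size open) in size. A report of only a limit is again likely for compound 4. For compound 4 the estimated value is 100 ug/mL with an expected range from 45 ug/mL to 200 ug/mL on the same read-out.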

Compound 4, half-maximal cytotoxic concentration: > 100 ug/mL
Compound 4 gave a limit, no number; the forecaster's own chance of this, stated with the estimate: 70%; the middle value lies on the limit itself.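

In this assay no step can be read from compound 3 to compound 4, because both give only a limit: the limit of > 100 ug/mL in this assay, at which 4 of the 4 values shown sit. The compounds shown leave open whether isopropyl in place of methyl on a saturated ring carbon alters the half-maximal cytotoxic concentration at all.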